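Urea aryl swap: chloro for trifluoromethyl

This account rests on a few compounds, and the source may have more. Where it says the series, first, only, none or still open, it means among the compounds named here.

For the measured compounds named here, compound 2 `COc1cc2cc(Oc3ccc(NC(=O)Nc4ccc(Cl)c(C(F)(F)F)c4)cc3)c(C)nc2cc1OC` stands lowest of the two numbers so far in a functional assay on SN12C cells (Homo sapiens) for inhibition, read by sulforhodamine B assay, with a stated time of 48 h, tested at 10 uM (on this read-out lower numbers stand for a stronger effect and higher numbers for a weaker effect at the one concentration tested), where compound 2 gives 13.2%. Going by the values given here, its only neighbour is compound 1 `COc1cc2cc(Oc3ccc(NC(=O)Nc4ccc(C(F)(F)F)cc4)cc3)c(C)nc2cc1OC`, which in this assay gives 72.2%; the step of a number 59 percentage points lower from compound 1 to compound 2 (beyond the scatter) is the one measured change. Compound 3 `COc1cc2cc(Oc3ccc(NC(=O)Nc4ccc(Cl)c(Cl)c4)cc3)c(C)nc2cc1OC` differs from compound 2 by chloro in place of trifluoromethyl on an aromatic carbon. Among the compounds with values here, no measured step exchanges these two groups on this ring, so the step from compound 1 to compound 2, large as it is, bears on the present change only loosely: it shows that this part of the urea aryl ring sets the read-out strongly. The exchange here keeps the chloro group ortho to the entering chloro and removes the trifluoromethyl, so the expected step of a number 11.8 percentage points higher from compound 2 to compound 3 (beyond the scatter) is a modest weakening that may stay within the scatter. Compound 3 is accordingly estimated at 25%, within 8% to 55%.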

Compound 3, a percentage reported as activity, at one concentration (the size of the read-out at that concentration, not a potency): 22.1%
Compound 3: the middle estimate sits 2.9 percentage points above what was measured, and the stated range covers the measured number.
By their numbers in this assay, from the lowest: compounds 2 and 3 (each within the scatter of the next); then compound 1.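

The step of a number 8.9 percentage points higher from compound 2 to compound 3 (within the scatter) shows that in this assay, chloro can replace trifluoromethyl on this aromatic carbon, ortho to a chloro group, without a difference the read-out can resolve. The step of a number 50.1 percentage points lower from compound 1 to compound 3 (beyond the scatter) shows that the large difference first seen with 4-chloro-3-(trifluoromethyl)phenyl also appears with 3,4-dichlorophenyl, so among these three compounds it does not depend on a trifluoromethyl group being present on this carbon. The data shown offer no explanation for either step.

As far as these compounds go, it remains open how a nitrile, a methoxy group or an amine on this carbon would read in this assay. Also open, from the compounds shown here alone, is how a ring carrying only the chloro group, with hydrogen on this carbon, would compare with compound 2 and compound 3.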